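This account rests on a few compounds, and the source may have more. Where it says the series, first, only, none or still open, it means among the compounds named here.

Measured so far:
Compound 1 `CN(C)c1ccc(NC(=O)[C@H](CCCCCC(=O)NO)NC(=O)OCc2ccccc2)cc1` — in a functional assay on NFF cells (Homo sapiens) for antiproliferative activity (a lower number here means a stronger inhibitor, a higher number a weaker inhibitor), compound 1 gives 650 nM.
Compound 2 `CN(C)c1ccc(NC(=O)[C@H](CCCCCC(=O)NO)NC(=O)c2ccc(C(F)(F)F)cc2)cc1` — in this assay compound 2 gives 400 nM.

Compound 1 stands at the highest of the two numbers; its nearest neighbour is compound 2, and the step of a 1.6-fold lower number from compound 1 to compound 2 (0.21 log units; within the scatter) lies within the scatter, so no order between the two is claimed.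

Compound 3 `O=C(CCCCC[C@H](NC(=O)OCc1ccccc1)C(=O)NC1CCCc2ccccc21)NO` is not yet measured. It differs from compound 1 by 1,2,3,4-tetrahydronaphthalen-1-yl in place of 4-(dimethylamino)phenyl on an amide-type nitrogen. Within the data shown here, the one measured step, a 1.6-fold lower number from compound 1 to compound 2 (0.21 log units; within the scatter), concerns a group on a carbonyl carbon and not the amide-type nitrogen changed here, and it was within the scatter in any case. Among the measured compounds shown here, no measured pair informs the exchange of 4-(dimethylamino)phenyl for 1,2,3,4-tetrahydronaphthalen-1-yl. No step beyond the scatter is therefore expected in either direction, with wide uncertainty. Compound 3 is expected near 700 nM, with a range of 150 nM to 3000 nM. The expected step is a 1.1-fold higher number from compound 1 to compound 3 (0.03 log units; within the scatter).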

Compound 3, half-maximal inhibitory concentration: 1700 nM
Compound 3: middle estimate off by 2.4-fold (0.39 log units), on the low side; measured number inside the range.
By their numbers in this assay, from the lowest: compounds 2 and 1 (each within the scatter of the next); then compound 3.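

Among these compounds, at the amide-type nitrogen, the exchange of 4-(dimethylamino)phenyl for 1,2,3,4-tetrahydronaphthalen-1-yl gives the first step beyond the scatter in this assay: a 2.6-fold higher number from compound 1 to compound 3 (0.42 log units; beyond the scatter) and this step is modest. This position therefore responds to the group it carries, and in this one pair the number is lower with 4-(dimethylamino)phenyl. No measured information accounts for the step.

The exchange alters several things at once, including the dimethylamino nitrogen, the non-aromatic ring and the link from the amide-type nitrogen to the aromatic ring, so the compounds shown cannot say which of these matters; an unsubstituted phenyl on the same nitrogen would help separate them. Also open, going by these compounds, is whether the step holds when 4-(trifluoromethyl)phenyl replaces benzyloxy on the carbonyl carbon.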